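Swapping Ethoxy for Hydroxymethyl on the Biaryl Tail

The source may report more compounds than this note shows. Statements on the series, on what has been measured and on what is new or still open speak of the compounds shown alone.

Compound 3 `CCOc1ccc(-c2ccc(N(C[C@@H](N)[C@@H](C)CC)C(=O)[C@@H]3C[C@H]3c3ccccc3)cc2)cc1` gives 90 nM in a functional assay for agonist activity at G protein-coupled receptor 88 (Homo sapiens), read by HTRF and cAMP accumulation (a lower number here means that less compound is needed, a higher number that more compound is needed for the effect), the second highest of three numbers. Compound 1 `CCCc1ccc(-c2ccc(N(C[C@@H](N)[C@@H](C)CC)C(=O)[C@@H]3C[C@H]3c3ccccc3)cc2)cc1` gives 61 nM, and the step of a 1.5-fold higher number from compound 1 to compound 3 (0.17 log units; within the scatter) stays within the scatter, whereas compound 2 `CC[C@H](C)[C@H](N)CN(C(=O)[C@@H]1C[C@H]1c1ccccc1)c1ccc(-c2ccc(C(C)(C)C)cc2)cc1` gives 750 nM, and the step of an 8.3-fold lower number from compound 2 to compound 3 (0.92 log units; beyond the scatter) lies beyond it. Compound 4 `CC[C@H](C)[C@H](N)CN(C(=O)[C@@H]1C[C@H]1c1ccccc1)c1ccc(-c2ccc(CO)cc2)cc1` differs from compound 3 by hydroxymethyl in place of ethoxy on an aromatic carbon. Both measured steps alter this same position, and they show that the number moves with what sits there, yet neither adds a hydrogen-bond donor, so they guide only loosely. With that gap in the data, a modest rise in this assay is expected, amounting to a 3.3-fold higher number from compound 3 to compound 4 (0.52 log units; beyond the scatter). Compound 4 is therefore estimated at 300 nM, within a range from 80 nM to 1200 nM.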

Compound 4, half-maximal effective concentration: 1100 nM
Estimate against measurement, compound 4: 3.7-fold (0.56 log units) below; low and high end bracket the measured number.
By their numbers in this assay, from the lowest: compounds 1 and 3 (each within the scatter of the next); then compounds 2 and 4 (each within the scatter of the next).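

In this assay, hydroxymethyl is the only group shown here at this position that carries a hydrogen-bond donor, and it brings a 12-fold higher number from compound 3 to compound 4 (1.09 log units; beyond the scatter) and an 18-fold higher number from compound 1 to compound 4 (1.26 log units; beyond the scatter) as well. The comparison with tert-butyl gives a 1.5-fold higher number from compound 2 to compound 4 (0.17 log units; within the scatter), so these two quite different groups end up within the scatter of each other. Nothing measured here accounts for the rise.

The change adds a donor and also makes the group smaller, which leaves open which of the two matters. From the compounds shown here alone, how a methoxy group or a longer chain ending in hydroxy would behave at this position also remains open.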